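Indole enones: nitro on the benzoyl ring of compound 2

This account rests on a few compounds, and the source may have more. Where it says the series, first, only, none or still open, it means among the compounds named here.

Three compounds sharing one core have been run in a functional assay on DU-145 cells (Homo sapiens) for cytotoxicity, read by MTT assay, with a stated time of 96 h; on this read-out higher numbers stand for an effect only at larger amounts of compound and lower numbers for an effect already at smaller amounts. Compound 1 `O=C(/C(=C\c1c(-c2ccccc2)[nH]c2ccccc12)C(=O)C(F)(F)F)c1ccco1` gives 9200 nM in this assay. Compound 3 `N#C/C(=C\c1c(-c2ccccc2)[nH]c2ccccc12)C(=O)c1cccs1` gives 11000 nM in this assay. Compound 2 `CCOC(=O)/C(=C/c1c(-c2ccccc2)[nH]c2ccccc12)C(=O)c1ccccc1`, which carries an ethyl ester and a benzoyl group on the exocyclic double bond, gives 68000 nM in this assay; this is the highest of the three numbers, and compound 1 and compound 3 both sit lower by more than the scatter, so compound 2 is the weakest member of the measured set on this read-out.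

Compound 4 `CCOC(=O)/C(=C/c1c(-c2ccccc2)[nH]c2ccccc12)C(=O)c1ccc([N+](=O)[O-])cc1` keeps the ester and the benzoyl group of compound 2 and differs from it in one place: nitro in place of hydrogen on an aromatic carbon. For the measured compounds named here, no measured pair in the set carries this change, so nothing within the data shows how it moves the number in this assay. The expected step is a 1.7-fold lower number from compound 2 to compound 4 (0.23 log units; within the scatter), a modest move toward a lower number whose size may not clear the scatter. Compound 4 is therefore estimated at 40000 nM in this assay, with a range from 12000 nM to 120000 nM.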

Compound 4, half-maximal effective concentration: 11000 nM
Estimate against measurement, compound 4: 3.6-fold (0.56 log units) above; measured number below the stated range.
By their numbers in this assay, from the lowest: compounds 1, 3 and 4 (each within the scatter of the next); then compound 2.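

For the compounds shown here, in a 6.2-fold lower number from compound 2 to compound 4 (0.79 log units; beyond the scatter) in this assay, nitro in place of hydrogen on an aromatic carbon supplies the first measured single-place step, and it lies beyond the scatter. The benzoyl ring of compound 2 is therefore not a silent place on this read-out: with the ethyl ester and the shared core held fixed, a group of 3 heavy atoms entering para to a large group moves the number to a clear degree. No measurement at hand accounts for this step or ties it to any property of the nitro group.

The compounds shown hold no amine, methoxy group or carboxylic acid at this ring carbon, so it remains open whether the step is particular to nitro or would also follow from other groups placed there. Also open, from the compounds shown here alone, is whether nitro gives a step of similar size and direction when the ethyl ester is exchanged for a nitrile or a longer chain ester.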